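Swapping cyclopentyl for isopropoxy on a carbonyl carbon

The compounds below may be only part of what the source reports. "The series", "measured", "known", "first", "only" and "open" are said of these compounds alone.

Measured so far in a physicochemical assay for lipophilicity, at pH 7.4 (a lower number here means a more polar compound, a higher number a more lipophilic compound), for three compounds
Compound 1 `Cc1cc(C(=O)NN2CCCCC2)nn1Cc1cc(Cl)ccc1OCC(C)C` gives 3.3
Compound 2 `Cc1cc(C(=O)NN2CCOCC2)nn1Cc1cc(Cl)ccc1OCC(C)C` gives 3.1
Compound 3 `Cc1cc(NC(=O)C2CCCC2)nn1Cc1cc(Cl)ccc1OCC(C)C` gives > 3.7 (a limit)

Compound 3 gives > 3.7 as a limit of the assay, not a number. It stands highest of the three, with a number at least 0.40 log units higher from compound 1 to compound 3 (beyond the scatter) and a number at least 0.60 log units higher from compound 2 to compound 3 (beyond the scatter) as its measured gaps. The change to compound 4 `Cc1cc(NC(=O)OC(C)C)nn1Cc1cc(Cl)ccc1OCC(C)C` is isopropoxy in place of cyclopentyl on a carbonyl carbon in short, isopropoxy in place of cyclopentyl on a carbonyl carbon. Among the measured compounds shown here, no measured step makes this exact swap, but the nearest, morpholin-4-yl in place of piperidin-1-yl on an amide-type nitrogen, also brings in an oxygen and gave a number 0.20 log units lower from compound 1 to compound 2 (within the scatter) only. A small fall, possibly none beyond the scatter, is therefore expected, an estimated a number at least 0.10 log units lower from compound 3 to compound 4 (that floor lies within the scatter) in all. Compound 4 is estimated at 3.6 (expected range 3.1 to 4.1).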

Compound 4, distribution coefficient: > 3.7
Compound 4: only a limit was reported; the forecaster's own chance of this, stated with the estimate: 45%; middle value at least 0.10 log units from the limit.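

In this assay, compound 4 gives > 3.7, which is a limit and not a number, so on this carbonyl carbon isopropoxy, with its oxygen, reaches the same limit as cyclopentyl. Among the compounds shown here, its gaps to the earlier compounds remain clear: a number at least 0.60 log units higher from compound 2 to compound 4 (beyond the scatter), and a number at least 0.40 log units higher from compound 1 to compound 4 (beyond the scatter). The step from compound 3 to compound 4 cannot be read, because both compounds sit at one limit: the limit of > 3.7 in this assay, at which 2 of the 4 values shown sit.

On these data alone, how far apart isopropoxy and cyclopentyl truly lie stays open. Also open, as far as these compounds go, is what an amine or a longer chain would give on this carbonyl carbon.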